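Carbamate ester variation and stability in a liver fraction

A few compounds are considered here, and "the series" means these few. Any claim that something is new, unique, unknown or untested is made for them only; others in the source may bear on it.

Three compounds share one core and differ only in the ester of a carbamate. Compound 1 `CCOC(=O)N1CCN(C(=O)c2nc(Nc3cc(C4CC4)[nH]n3)c3cc(Cl)ccc3n2)C[C@H]1C` gives 48.5% in an ADME assay on S9 fraction from liver (Rattus norvegicus), read by LC-MS, with a stated time of 60 min, at 37 degrees C; a lower number here means that less of the compound is left, a higher number that more of the compound is left. Compound 2 `CCCCCOC(=O)N1CCN(C(=O)c2nc(Nc3cc(C4CC4)[nH]n3)c3cc(Cl)ccc3n2)C[C@H]1C` gives 63.9% in this assay, and compound 3 `C[C@@H]1CN(C(=O)c2nc(Nc3cc(C4CC4)[nH]n3)c3cc(Cl)ccc3n2)CCN1C(=O)OCc1ccccc1` gives 45.6% in this assay. Compound 3 thus holds the lowest of the three numbers, yet its nearest neighbour is compound 1, as a number 2.9 percentage points lower from compound 1 to compound 3 (within the scatter) shows, a gap within the scatter; the gap to compound 2, a number 18.3 percentage points lower from compound 2 to compound 3 (beyond the scatter), lies beyond the scatter.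

Compound 4 `CC(C)OC(=O)N1CCN(C(=O)c2nc(Nc3cc(C4CC4)[nH]n3)c3cc(Cl)ccc3n2)C[C@H]1C` has not yet been measured. It differs from compound 3 in one place: isopropyl in place of benzyl on an oxygen next to a carbonyl group. Two kinds of measured step bear on this. Lengthening the chain gave a number 15.4 percentage points higher from compound 1 to compound 2 (beyond the scatter), while exchanging a chain for a ring gave a number 2.9 percentage points lower from compound 1 to compound 3 (within the scatter) and a number 18.3 percentage points lower from compound 2 to compound 3 (beyond the scatter). Isopropyl, like ethyl and pentyl, carries no ring, so compound 4 is expected to sit near or somewhat above compound 3, with a number 6.4 percentage points higher from compound 3 to compound 4 (within the scatter) expected to remain within the scatter. Compound 4 is therefore estimated at 52% in this assay, with a range from 40% to 64%.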

Compound 4, percent of the compound remaining: 78.6%
For compound 4 the middle estimate is 26.6 percentage points below the measured one; measured number above the stated range.
By their numbers in this assay, from the lowest: compounds 3 and 1 (each within the scatter of the next); then compound 2; then compound 4.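

Within the data shown here, at this position, a single methyl added to the saturated chain carbon bound to the oxygen moved the result further than any change among the earlier compounds, with a number 30.1 percentage points higher from compound 1 to compound 4 (beyond the scatter) in this assay. Chain length alone does not set the order of these carbamates: isopropyl also outdoes the longer pentyl, with a number 14.7 percentage points higher from compound 2 to compound 4 (beyond the scatter), so the rise seen earlier on going from ethyl to pentyl does not describe the whole series. Ethyl and benzyl had given values within the scatter of each other, which made this oxygen look rather insensitive, but a number 33 percentage points higher from compound 3 to compound 4 (beyond the scatter) shows a wide span of results there, and no measurement at hand accounts for it.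

The compounds shown leave open whether the branch itself matters, as an unbranched propyl chain on the same oxygen would show, and whether a tert-butyl or cyclopentyl group would go beyond isopropyl. They also leave open which part of each molecule is consumed during the incubation, since the read-out follows only the compound that remains.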